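Methoxymethyl in place of phenyl: an expected step

The source may report more compounds than this note shows. Statements on the series, on what has been measured and on what is new or still open speak of the compounds shown alone.

Measured in a functional assay (Nicotiana tabacum); on this read-out higher numbers stand for weaker inhibition and lower numbers for stronger inhibition:
Compound 1 `CCCCCCCNc1nc(SC)nc2ncccc12`: 4070 nM
Compound 2 `CSc1nc(NCc2ccccc2)c2cccnc2n1`: 25200 nM

Compound 2 has the higher number of the pair, so it is the weaker inhibitor. Compound 3 `COCCNc1nc(SC)nc2ncccc12` carries methoxymethyl in place of phenyl on a saturated chain carbon bound to a nitrogen on an aromatic ring. Among the compounds with values here, no measured compound carries this group. Within the data shown here, the only measured step, a 6.2-fold higher number from compound 1 to compound 2 (0.79 log units; beyond the scatter), changed the group at this same place, so a step of similar size or smaller, again upward, is expected in this assay. The expected change is a 2.2-fold higher number from compound 2 to compound 3 (0.34 log units; beyond the scatter). For compound 3 the estimated value is 55000 nM, with an expected range of 16000 nM to 180000 nM.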

Compound 3, half-maximal inhibitory concentration: 2530 nM
Estimate against measurement, compound 3: 22-fold (1.34 log units) above; the measured number lies below the stated range.
By their numbers in this assay, from the lowest: compounds 3 and 1 (each within the scatter of the next); then compound 2.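

In this assay, methoxymethyl in place of phenyl on a saturated chain carbon bound to a nitrogen on an aromatic ring gives a 10-fold lower number from compound 2 to compound 3 (1.00 log units; beyond the scatter), so among these compounds the phenyl of compound 2 alone stands apart. Methoxy in place of pentyl gives a 1.6-fold lower number from compound 1 to compound 3 (0.21 log units; within the scatter), which leaves these two chain ends unseparated on this read-out despite their different lengths. Nothing available explains why phenyl differs from both chains.

On these data alone, whether a basic amine or a carboxylic acid at the chain end would keep this level stays open. So does whether a longer chain between the nitrogen and the phenyl would recover it.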